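Z to E double bond: compound 2 to compound 3

The source may report more compounds than this note shows. Statements on the series, on what has been measured and on what is new or still open speak of the compounds shown alone.

Compound 1 `COc1cc(/C=C/Cc2cc(O)c3cc(C)oc3c2)cc(OC)c1OC`: 12300 nM
Compound 2 `COc1cc(/C=C\Cc2cc(O)c3cc(-c4ccccc4)oc3c2)cc(OC)c1OC`: > 2000 nM (a limit)

Both readings come from a functional assay on BMEC cells (Bos taurus) for antiproliferative activity; on this read-out lower numbers stand for stronger inhibition and higher numbers for weaker inhibition. Compound 2 stands at > 2000 nM, which is a limit of the assay and not a number. Compound 1 gives a number, 12300 nM, and has its double bond drawn E, but it is not otherwise the same as compound 3 `COc1cc(/C=C/Cc2cc(O)c3cc(-c4ccccc4)oc3c2)cc(OC)c1OC`.

Compound 3 has the same atoms and bonds as compound 2, and the two differ only in configuration as drawn: the two compounds have the same atoms and bonds and differ only in configuration as drawn: 1 of 1 stereo elements differ; a double bond is drawn Z in compound 2 and E in compound 3. For the measured compounds named here, no measured pair in this set isolates that change, so the size of the step has no direct support. Going by the values given here, the expectation rests on compound 1 at 12300 nM, the only number available with the double bond drawn E. For compound 3 the expected value is 8000 nM, with an estimated range of 2500 nM to 30000 nM. A step toward weaker inhibition in this assay is therefore expected, of moderate size and uncertain, with a step that the limit leaves unreadable from compound 2 to compound 3 as the estimated step.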

Compound 3, half-maximal inhibitory concentration: > 20000 nM
Compound 3: no number, only a limit (the forecaster's own chance of this, stated with the estimate: 35%); middle value at least 2.5-fold (0.39 log units) from the limit.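

In this assay compound 3 stands at > 20000 nM, which is a limit of the assay and not a number, so the phenyl compound with the double bond drawn E has no measured potency. Phenyl in place of methyl on an aromatic carbon gives an at least 1.6-fold higher number from compound 1 to compound 3 (0.21 log units; that floor lies within the scatter), so this reading shows no gain in inhibition from phenyl at this position with the double bond drawn E, and no firm loss either. Compound 2 and compound 3 each carry only a limit, so the step between them cannot be read and no effect of Z against E is shown: the fact that compounds 2 and 3 differ only in the configuration as drawn

From the compounds shown here alone, how compound 2 and compound 3 rank in this assay stays open, as does the value of a compound with methyl on the aromatic carbon and the double bond drawn Z. Also open is how an amine or a carboxylic acid in place of phenyl on that aromatic carbon would read in this assay.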